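Exchanging the Chlorophenyl on the Cyclopropane of Compound 3

A few compounds are considered here, and "the series" means these few. Any claim that something is new, unique, unknown or untested is made for them only; others in the source may bear on it.

Of the compounds shown here, three sharing one core have been measured in a functional assay for agonist activity at G protein-coupled receptor 88 (Homo sapiens), read by HTRF and cAMP accumulation; a lower number here means that less compound is needed, a higher number that more compound is needed for the effect. For the measured compounds named here, compound 1 `CC(C)[C@H](N)CN(C(=O)[C@@H]1C[C@H]1c1ccccc1)c1ccc(-c2ccccc2)cc1` gives 1.1 nM and compound 2 `NC1(CN(C(=O)[C@@H]2C[C@H]2c2ccccc2)c2ccc(-c3ccccc3)cc2)CCCC1` gives 0.57 nM; the only single-point step, a 1.9-fold lower number from compound 1 to compound 2 (0.29 log units; within the scatter), concerns the amine-bearing side chain. Compound 3 `CC[C@H](C)[C@H](N)CN(C(=O)[C@@H]1C[C@H]1c1ccc(Cl)cc1)c1ccc(-c2ccccc2)cc1` gives 4300 nM, the highest of the three numbers, far from both others. Compound 4 `CC[C@H](C)[C@H](N)CN(C(=O)[C@@H]1C[C@H]1c1cc(F)cc(F)c1)c1ccc(-c2ccccc2)cc1` differs from compound 3 by 3,5-difluorophenyl in place of 4-chlorophenyl on a saturated ring carbon. Going by the values given here, no measured step touches the aryl on the three-membered ring, and compound 1 differs from compound 3 in two places, so the comparison offers no guidance. Compound 4 is therefore expected to stay near compound 3, an estimated 1.4-fold lower number from compound 3 to compound 4 (0.16 log units; within the scatter), giving an expected 3000 nM with a wide range from 300 nM to 30000 nM.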

Compound 4, half-maximal effective concentration: 960 nM
Beside the measured number, compound 4's estimate is 3.1-fold (0.49 log units) above it; the range from low to high includes it.
By their numbers in this assay, from the lowest: compounds 2 and 1 (each within the scatter of the next); then compound 4; then compound 3.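

In this assay, the aryl on the three-membered ring now has its first measured step: 3,5-difluorophenyl in place of 4-chlorophenyl gives a 4.5-fold lower number from compound 3 to compound 4 (0.65 log units; beyond the scatter). For the compounds shown here, the position therefore responds to the aryl's substitution, although this single modest step shows only one exchange. Nothing available explains the shift.

As far as these compounds go, whether a 4-fluorophenyl, a 3,5-dichlorophenyl or a pyridine ring would shift the number further remains open. So does whether the same exchange would act alike on the 1-aminocyclopentyl side chain of compound 2.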